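Same Methyl Step Twice: Expecting the Cell Toxicity of Compound 4

The source may report more compounds than this note shows. Statements on the series, on what has been measured and on what is new or still open speak of the compounds shown alone.

Compound 1 `C/C(=N\Nc1nc(C)cs1)c1ccc(Cl)c(Cl)c1`: 26100 nM
Compound 2 `C/C(=N\Nc1nc(C)c(C)s1)c1ccc(Cl)c(Cl)c1`: a limit only, > 50000 nM
Compound 3 `C/C(=N\Nc1nc(-c2ccc(Br)cc2)cs1)c1ccc(Cl)c(Cl)c1`: a limit only, > 50000 nM

In an ADME assay on H9c2 cells (Rattus norvegicus) for cytotoxicity, read by resazurin assay, with a stated time of 72 h (on this read-out higher numbers stand for lower toxicity in this test and lower numbers for higher toxicity in this test), compound 1 gives 26100 nM. For compound 2 the assay reports only a limit, > 50000 nM. For compound 3 it likewise reports only a limit, > 50000 nM. The change methyl in place of hydrogen on an aromatic carbon gave an at least 1.9-fold higher number from compound 1 to compound 2 (0.28 log units; that floor lies within the scatter); the change 4-bromophenyl in place of methyl on an aromatic carbon gave an at least 1.9-fold higher number from compound 1 to compound 3 (0.28 log units; that floor lies within the scatter). Both steps end at the limit of > 50000 nM in this assay, at which 2 of the 3 values shown sit.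

Compound 4 `C/C(=N\Nc1nc(-c2ccc(Br)cc2)c(C)s1)c1ccc(Cl)c(Cl)c1` is not yet measured. It differs from compound 3 by methyl in place of hydrogen on an aromatic carbon, the same kind of change as from compound 1 to compound 2, though here the place sits next to the ring atom that bears a 4-bromophenyl group rather than a methyl group. Because compound 3 already sits at the limit of > 50000 nM in this assay, at which 2 of the 3 values shown sit, and the earlier step of an at least 1.9-fold higher number from compound 1 to compound 2 (0.28 log units; that floor lies within the scatter) pointed the same way, compound 4 is expected to show a step that the limit leaves unreadable from compound 3 to compound 4. Compound 4 is thus estimated at 70000 nM, in the range 30000 nM to 200000 nM.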

Compound 4, half-maximal cytotoxic concentration: > 50000 nM
Compound 4 gave a limit, no number (the forecaster's own chance of this, stated with the estimate: 75%); the middle value lies beyond the limit too.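

Compound 2, compound 3 and compound 4 all end at a limit, so the steps from compound 3 and from compound 2 to compound 4 cannot be read: the limit of > 50000 nM in this assay, at which 3 of the 4 values shown sit.

The compounds shown leave open how far past that limit their true numbers lie, and so whether methyl in place of hydrogen changes anything between compound 3 and compound 4.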